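The source may report more compounds than this note shows. Statements on the series, on what has been measured and on what is new or still open speak of the compounds shown alone.

Compound 1, `O=C(Nc1cc(C(F)(F)F)cc(C(F)(F)F)c1)c1cnc(Cl)nc1C(F)(F)F`, gives 50 nM in an assay on Jurkat cells for inhibition of nuclear factor NF-kappa-B p105 subunit (Homo sapiens); on this read-out lower numbers stand for stronger inhibition and higher numbers for weaker inhibition.
Compound 2, `CCOC(=O)c1cc(NC(=O)c2cnc(Cl)nc2C(F)(F)F)cc(C(F)(F)F)c1`, gives 280 nM in this assay.
Compound 3, `CCCCCCCCOC(=O)c1cc(NC(=O)c2cnc(Cl)nc2C(F)(F)F)cc(C(F)(F)F)c1`, gives 1800 nM in this assay.

Among these three, compound 3 gives the highest number, so it is the weakest inhibitor shown: compound 2 is nearest, with a 6.4-fold higher number from compound 2 to compound 3 (0.81 log units; beyond the scatter) separating them, and compound 1 is furthest, with a 36-fold higher number from compound 1 to compound 3 (1.56 log units; beyond the scatter) between them. Compound 4, `O=C(OC1CCCCC1)c1cc(NC(=O)c2cnc(Cl)nc2C(F)(F)F)cc(C(F)(F)F)c1`, differs from compound 3 in one place: cyclohexyl in place of octyl on an oxygen next to a carbonyl group. The measured step that bears most directly on this is the one from the ethyl ester to the octyl ester, a 6.4-fold higher number from compound 2 to compound 3 (0.81 log units; beyond the scatter), where lengthening the ester chain raised the number. Among the compounds with values here, compound 4 carries a six-carbon ring in place of the eight-carbon chain, so it sits between compound 2 and compound 3 in carbon count, and its number in this assay is expected to fall between their two values, though no measured step covers a ring in this position. The step of a 2.3-fold lower number from compound 3 to compound 4 (0.35 log units; beyond the scatter) is therefore expected. Compound 4 is estimated at 800 nM, with a range from 250 nM to 2500 nM.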

Compound 4, half-maximal inhibitory concentration: 1800 nM
The estimate for compound 4 lay 2.3-fold (0.35 log units) below the measured number; the range from low to high includes it.
By their numbers in this assay, from the lowest: compound 1; then compound 2; then compounds 3 and 4 (each within the scatter of the next).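

In this assay replacing the open octyl chain on this ester oxygen with the cyclohexyl ring gives no change at the digits printed from compound 3 to compound 4 (within the scatter) and so the ring and the longer chain cannot be told apart at this position. Going from the ethyl ester to the cyclohexyl ester gives a 6.4-fold higher number from compound 2 to compound 4 (0.81 log units; beyond the scatter) and matches the rise seen with the octyl ester, which shows that a long open chain is not needed for that rise. The cyclohexyloxycarbonyl group also remains well behind trifluoromethyl, with a 36-fold higher number from compound 1 to compound 4 (1.56 log units; beyond the scatter) and no outside data on these compounds offer an explanation for these numbers. Still open, from the compounds shown here alone, is whether a methyl ester or a free carboxylic acid at this position would come closer to compound 1. A cyclopropyl ester would also show whether a smaller ring behaves like ethyl or like cyclohexyl.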